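Swapping pyridin-2-yl for 1,3-thiazol-2-yl in compound 4

A few compounds are considered here, and "the series" means these few. Any claim that something is new, unique, unknown or untested is made for them only; others in the source may bear on it.

Measured so far in an assay on RBL-1 cells for inhibition of Polyunsaturated fatty acid 5-lipoxygenase (Rattus norvegicus); on this read-out higher numbers stand for weaker inhibition and lower numbers for stronger inhibition:
compound 1, `CCc1cccc(N2CCNC(=O)N2)c1`, compound 1 gives 13000 nM
compound 2, `CSc1cccc(N2CCNC(=O)N2)c1`, compound 2 gives 14000 nM
compound 3, `O=C1NCCN(c2cccc(-c3ccccn3)c2)N1`, compound 3 gives 30000 nM

All three share the same core and differ only in the group on one aromatic carbon. Compound 3 has the highest number of the three in this assay: the step of a 2.3-fold higher number from compound 1 to compound 3 (0.36 log units; beyond the scatter) and the step of a 2.1-fold higher number from compound 2 to compound 3 (0.33 log units; beyond the scatter) are both modest but beyond the scatter, while the step of a 1.1-fold higher number from compound 1 to compound 2 (0.03 log units; within the scatter) is within it.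

Compound 4, `O=C1NCCN(c2cccc(-c3nccs3)c2)N1`, is compound 3 with one change: 1,3-thiazol-2-yl in place of pyridin-2-yl on an aromatic carbon. One five-membered aromatic ring with two hetero atoms thus takes the place of a six-membered aromatic ring with one hetero atom, at the same position.

Among the compounds with values here, no measured pair shows this exact exchange. Within the data shown here, the only steps that touch compound 3 replace a small non-aromatic group with pyridin-2-yl, and those steps were modest. An exchange of one aromatic heterocycle for another of similar size is expected to move this assay by no more than a modest step, with no clear direction. Compound 4 is therefore estimated at 25000 nM, expected within 10000 nM to 60000 nM, a step of a 1.2-fold lower number from compound 3 to compound 4 (0.08 log units; within the scatter) relative to compound 3.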

Compound 4, half-maximal inhibitory concentration: 35000 nM
Compound 4: middle estimate off by 1.4-fold (0.15 log units), on the low side; the range from low to high includes it.
By their numbers in this assay, from the lowest: compounds 1 and 2 (each within the scatter of the next); then compounds 3 and 4 (each within the scatter of the next).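

In this assay, within the data shown here, a five-membered aromatic ring with sulfur and nitrogen takes the place of a six-membered aromatic ring with one nitrogen, and the two cannot be told apart at this aromatic carbon (a 1.2-fold higher number from compound 3 to compound 4 (0.07 log units; within the scatter)); the earlier compounds, with only one aromatic ring here, could not show this. The 1,3-thiazol-2-yl group also stands apart from both small groups, with modest steps beyond the scatter from methylsulfanyl (a 2.5-fold higher number from compound 2 to compound 4 (0.40 log units; beyond the scatter)) and from ethyl (a 2.7-fold higher number from compound 1 to compound 4 (0.43 log units; beyond the scatter)), so among these four compounds, compound 3 and compound 4, the two with a ring at this place, give the higher numbers. Nothing measured in this set explains these numbers or why the two rings match.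

The compounds shown leave open whether an amine, a carboxylic acid or a longer chain on this same carbon would bring the number below those of compound 1 and compound 2. They also leave open whether a plain phenyl ring, with no hetero atom at all, would fall with compound 3 and compound 4 or with the two small groups.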